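The compounds below may be only part of what the source reports. "The series", "measured", "known", "first", "only" and "open" are said of these compounds alone.

Compound 1 `COc1ccc(CNC(=O)/C(C#N)=C/c2ccc(C)o2)cc1` gives 75000 nM in a functional assay on SJ-G2 cells (Homo sapiens) for inhibition, read by MTT assay, with a stated time of 72 h; on this read-out higher numbers stand for weaker inhibition of growth and lower numbers for stronger inhibition of growth. Compound 2 `COc1ccc(CNC(=O)/C(C#N)=C/c2ccc(Cl)o2)cc1` carries the change (chloro in place of methyl on an aromatic carbon), and it gives 13000 nM in this assay, a step of a 5.8-fold lower number from compound 1 to compound 2 (0.76 log units; beyond the scatter). Compound 3 `COc1ccc(CNC(=O)/C(C#N)=C/c2ccc(C)cc2)cc1` differs from compound 1 in its core by 4-methylphenyl in place of 5-methylfuran-2-yl on a double-bonded chain carbon bound to a double-bonded chain carbon; in this assay compound 3 gives 39000 nM, a step of a 1.9-fold lower number from compound 1 to compound 3 (0.28 log units; within the scatter), while from compound 2 the step is a 3.0-fold higher number from compound 2 to compound 3 (0.48 log units; beyond the scatter). Compound 4 `COc1ccc(CNC(=O)/C(C#N)=C/c2ccc(Cl)cc2)cc1` is not yet measured and differs from compound 3 by chloro in place of methyl on an aromatic carbon. This is the same kind of change as that from compound 1 to compound 2, not the same one: there it sits on an aromatic carbon of a five-membered aromatic ring with 1 oxygen, next to the ring oxygen, here on an aromatic carbon of a six-membered aromatic ring of carbon only, para to a large group. Beside the earlier step of a 5.8-fold lower number from compound 1 to compound 2 (0.76 log units; beyond the scatter), a somewhat smaller step of a 3.9-fold lower number from compound 3 to compound 4 (0.59 log units; beyond the scatter) is expected for compound 4, because the single precedent a 5.8-fold lower number from compound 1 to compound 2 (0.76 log units; beyond the scatter) stands on a different ring. Compound 4 is therefore estimated at 10000 nM, between 3000 nM and 30000 nM.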

Compound 4, concentration for 50% growth inhibition: 11000 nM
Compound 4: middle estimate off by 1.1-fold (0.04 log units), on the low side; the range from low to high includes it.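

In this assay, chloro in place of methyl again lowers the number, a 3.5-fold lower number from compound 3 to compound 4 (0.55 log units; beyond the scatter), and the step agrees with the earlier one: the same change on two cores in this assay, a 5.8-fold lower number (0.76 log units; beyond the scatter) from compound 1 to compound 2 and a 3.5-fold lower number (0.55 log units; beyond the scatter) from compound 3 to compound 4, 1.6-fold (0.21 log units) apart, within the scatter of two such steps. The two chloro compounds show no difference beyond the scatter, a 1.2-fold lower number from compound 2 to compound 4 (0.07 log units; within the scatter), while 4-chlorophenyl in place of 5-methylfuran-2-yl gives a 6.8-fold lower number from compound 1 to compound 4 (0.83 log units; beyond the scatter). So the change carried over between these two cores in direction and, within the scatter, in size, but two pairs show neither why it does so nor that it would hold on any other core.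

The compounds shown leave open whether bromo, trifluoromethyl or an amine on the same aromatic carbon would follow chloro. They also leave open how a third core would respond.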